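Trifluoromethyl for fluoro at the pyrazole aryl

The source may report more compounds than this note shows. Statements on the series, on what has been measured and on what is new or still open speak of the compounds shown alone.

Compound 1 `O=S(=O)(c1ccccc1)n1c(-c2cn(-c3ccccc3)nc2-c2ccc(F)cc2)nc2ccccc21` gives 680 nM in a functional assay on HeLa cells (Homo sapiens) for antiproliferative activity, read by MTT assay, with a stated time of 24 h; on this read-out lower numbers stand for stronger inhibition and higher numbers for weaker inhibition. Compound 2 `O=S(=O)(c1ccc(F)cc1)n1c(-c2cn(-c3ccccc3)nc2-c2ccc(F)cc2)nc2ccccc21` gives 2440 nM, a step of a 3.6-fold higher number from compound 1 to compound 2 (0.55 log units; beyond the scatter). Compound 3 `O=S(=O)(c1ccc(C(F)(F)F)cc1)n1c(-c2cn(-c3ccccc3)nc2-c2ccc(F)cc2)nc2ccccc21` gives 1430 nM, a step of a 2.1-fold higher number from compound 1 to compound 3 (0.32 log units; beyond the scatter). Between the two substituted members the step is a 1.7-fold lower number from compound 2 to compound 3 (0.23 log units; within the scatter), made by trifluoromethyl in place of fluoro on an aromatic carbon.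

Compound 4 `O=S(=O)(c1ccccc1)n1c(-c2cn(-c3ccccc3)nc2-c2ccc(C(F)(F)F)cc2)nc2ccccc21` is not yet measured. It differs from compound 1 by trifluoromethyl in place of fluoro on an aromatic carbon, the same change as from compound 2 to compound 3. The core of compound 1 differs from that of compound 2 by hydrogen in place of fluoro on an aromatic carbon.

Within the data shown here, with only one prior instance of the change, itself within the scatter, the step from compound 1 to compound 4 in this assay is expected to be small, about a 1.4-fold lower number from compound 1 to compound 4 (0.13 log units; within the scatter), resting on compound 3 and compound 2 and their step of a 1.7-fold lower number from compound 2 to compound 3 (0.23 log units; within the scatter). Compound 4 is thus estimated at 500 nM, between 200 nM and 1500 nM.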

Compound 4, half-maximal inhibitory concentration: 560 nM
Beside the measured number, compound 4's estimate is 1.1-fold (0.05 log units) below it; measured number inside the range.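

Trifluoromethyl in place of fluoro on the core of compound 1 gives a small step in this assay, with a 1.2-fold lower number from compound 1 to compound 4 (0.08 log units; within the scatter), and the two steps for this change agree: the same change on two cores in this assay, a 1.7-fold lower number (0.23 log units; within the scatter) from compound 2 to compound 3 and a 1.2-fold lower number (0.08 log units; within the scatter) from compound 1 to compound 4, 1.4-fold (0.15 log units) apart, within the scatter of two such steps. The change therefore carries between these two cores without a difference that can be read, although it sits at a different place in each pair. This does not show that the change itself has a real effect on either core, since neither step lies beyond the scatter, and two pairs say nothing about other cores.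

As far as these compounds go, it remains open whether other groups at this place, such as methoxy, an amine or a carboxylic acid, would give a step beyond the scatter. Also open, from the compounds shown here alone, is how trifluoromethyl at both places in one compound would read.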